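The source may report more compounds than this note shows. Statements on the series, on what has been measured and on what is new or still open speak of the compounds shown alone.

Measured compounds:
compound 1 `COc1cc(OC)cc(-c2cc3ccccc3c(-c3cccc(OC)c3)n2)c1` gives 0%
compound 2 `COc1cc(OC)cc(-c2cc3ccccc3c(-c3cccc(N)c3)n2)c1` gives 0%
compound 3 `COc1cccc(-c2nc(-c3ccc(OC)c(OC)c3)cc3cc(C)ccc23)c1` gives 2.9%

All three were tested in an assay on isolated protein for inhibition of DNA topoisomerase 1 (Homo sapiens), with a stated time of 30 min, tested at 100 uM; a higher number here means a stronger effect of the compound at the concentration tested, a lower number a weaker effect. Compound 1 and compound 2 share one core and differ in a single place: amino in place of methoxy on an aromatic carbon. The step between them, no change at the digits printed from compound 1 to compound 2 (within the scatter), shows that this change made no difference that can be read here. Compound 3 sits on a second core; the difference between the two cores is not broken down here. Its result stands among the others without separating from them, since its value lies within the scatter of both compound 1 and compound 2.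

Compound 4 `COc1ccc(-c2cc3cc(C)ccc3c(-c3cccc(N)c3)n2)cc1OC` is the partner of compound 3 on that second core, and it has not yet been measured. The change from compound 3 to compound 4 is amino in place of methoxy on an aromatic carbon, and the place described for it is word for word the same as for the change from compound 1 to compound 2, so it is the same change, made here on the other core. Because the earlier occurrence gave no change at the digits printed from compound 1 to compound 2 (within the scatter), the expectation is that compound 4 will stay close to compound 3, with an expected step of a number 0.9 percentage points lower from compound 3 to compound 4 (within the scatter) in this assay. Compound 4 is therefore estimated at 2%, within a range from 0% to 10%, all of it inside the scatter of the values seen so far.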

Compound 4, a percentage reported as inhibition, at one concentration (the size of the read-out at that concentration, not a potency): 7.2%
The estimate for compound 4 lay 5.2 percentage points below the measured number, within the range that was stated.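

In this assay the exchange of 3-methoxyphenyl for 3-aminophenyl gave a number 4.3 percentage points higher from compound 3 to compound 4 (within the scatter) on the second core, and set beside its earlier occurrence it reads as follows: the same change on two cores in this assay, no change at the digits printed (within the scatter) from compound 1 to compound 2 and a number 4.3 percentage points higher (within the scatter) from compound 3 to compound 4, 4.3 percentage points apart, within the scatter of two such steps

Across the two cores shown, then, the change carried over in the plain sense that neither occurrence moved the result past the usual scatter, and nothing in these four compounds separates the response of one core from that of the other. This does not show that the change is without effect in general or that it would carry to a further core: it rests on two occurrences only, and all four compounds give small read-outs at the single concentration tested, where a difference that might appear among more active compounds could not be seen.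

The compounds shown leave open whether another group in that place, such as a hydroxyl, a dimethylamino group or an acetamide, would lift the read-out clear of the scatter on either core. Within the data shown here, they also leave open how the two cores compare as such, as these differ in more than one place and no single step connects them.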